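This account rests on a few compounds, and the source may have more. Where it says the series, first, only, none or still open, it means among the compounds named here.

Working notes on the series. For the measured compounds named here, in a functional assay on the whole organism for inhibition, with Rattus norvegicus as the target, read by paw edema, with stated times of 30 min and 2 h, at a dose of 10 mg/kg by the oral route (on this read-out higher numbers stand for more inhibition at the one dose given (going by the name of the read-out) and lower numbers for less inhibition), two compounds have numbers so far. Compound 1 `COc1ccc(C2CC(C3C(=O)c4ccccc4C3=O)=NC(=O)N2)cc1` gives 21% in this assay. Going by the values given here, compound 2 `CN(C)c1ccc(C2CC(C3C(=O)c4ccccc4C3=O)=NC(=O)N2)cc1` gives 29% in this assay, the higher of the two numbers, with compound 1 the nearest; the one measured step, a number 8 percentage points higher from compound 1 to compound 2 (within the scatter), lies within the scatter, so the two cannot be placed in order.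

Compound 3 `O=C1N=C(C2C(=O)c3ccccc3C2=O)CC(c2ccco2)N1` is not yet measured in this assay. It differs from compound 2 in one place: furan-2-yl in place of 4-(dimethylamino)phenyl on a saturated ring carbon. Among the compounds with values here, no measured step bears directly on this change; the only step known, a number 8 percentage points higher from compound 1 to compound 2 (within the scatter), concerns a substituent on the six-membered aromatic ring that is itself removed here, and it was within the scatter. The data give no footing for a change beyond the scatter in this assay in either direction, and the range must be set wide.

For compound 3 the expected number in this assay is 22%, with a range from 6% to 38%. This estimate means a step of a number 7 percentage points lower from compound 2 to compound 3 (within the scatter), expected to stay within the scatter.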

Compound 3, a percentage reported as inhibition, in the whole organism at one dose (the size of the read-out at that dose, not a potency): 25%
Compound 3: middle estimate off by 3 percentage points, on the low side; low and high end bracket the measured number.
By their numbers in this assay, from the lowest: compounds 1, 3 and 2 (each within the scatter of the next).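

At the saturated ring carbon next to the ring nitrogen, the change removes the whole six-membered aromatic ring and puts a five-membered aromatic ring with 1 hetero atom in its place. In this assay this exchange gives a number 4 percentage points lower from compound 2 to compound 3 (within the scatter) when 4-(dimethylamino)phenyl leaves, and a number 4 percentage points higher from compound 1 to compound 3 (within the scatter) when 4-methoxyphenyl leaves. The earlier compounds varied only a substituent on the six-membered aromatic ring, whereas these steps show that replacing the ring itself also leaves the three compounds impossible to place in order, and no measurement on hand gives a reason for this result.

Still open, going by these compounds, is whether a group of another kind on this ring carbon, such as an amine, a carboxylic acid or a longer alkyl chain, would give a step beyond the scatter in this assay. The compounds shown also leave open how far these numbers at one dose reflect potency, and whether changes elsewhere on the shared core would separate the compounds.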